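The source may report more compounds than this note shows. Statements on the series, on what has been measured and on what is new or still open speak of the compounds shown alone.

In a functional assay on CHO cells with adenosine receptor A1 (Homo sapiens) as the target, read by cAMP accumulation and immunoassay, with a stated time of 6 min, tested at 10 uM (on this read-out lower numbers stand for a stronger effect and higher numbers for a weaker effect at the one concentration tested), compound 2 `Nc1scc(CN2CCN(c3c(F)cccc3F)CC2)c1C(=O)c1ccc(Cl)cc1` gives -80%, the higher of the two numbers recorded, while compound 1 `Nc1scc(CN2CCN(c3ccc(F)c(F)c3)CC2)c1C(=O)c1ccc(Cl)cc1` gives -87%; the step of a number 7 percentage points higher from compound 1 to compound 2 (within the scatter) is the only one measured. Compound 3 `Nc1scc(CN2CCN(c3ccc(Cl)c(Cl)c3)CC2)c1C(=O)c1ccc(Cl)cc1` differs from compound 2 by 3,4-dichlorophenyl in place of 2,6-difluorophenyl on an amine nitrogen in a ring. The measured step of a number 7 percentage points higher from compound 1 to compound 2 (within the scatter) only moved two fluorines to other positions on the ring, so nothing recorded bears directly on replacing fluorine by chlorine. Compound 3 is therefore expected to stay close to compound 2, with a step of a number 3 percentage points lower from compound 2 to compound 3 (within the scatter). The estimate for compound 3 is -83%, ranging from -97% to -62%.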

Compound 3, a percentage reported as activity, at one concentration (the size of the read-out at that concentration, not a potency): -62%
Compound 3: the middle estimate sits 21 percentage points below what was measured; low and high end bracket the measured number.
By their numbers in this assay, from the lowest: compounds 1 and 2 (each within the scatter of the next); then compound 3.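

On an amine nitrogen in a ring, the identity of the halogen counts for more in this assay than the placement of the two fluorines did: 3,4-dichlorophenyl in place of 3,4-difluorophenyl gives a number 25 percentage points higher from compound 1 to compound 3 (beyond the scatter), a weaker effect with the substitution pattern unchanged. The exchange for 2,6-difluorophenyl, a number 18 percentage points higher from compound 2 to compound 3 (beyond the scatter), points the same way, though it alters halogen and placement together. No measurement at hand explains this shift. From the compounds shown here alone, how a 3-chlorophenyl, a 3,4-dimethoxyphenyl or an unsubstituted phenyl would read at this position stays open.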